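Trimming the Chain End of a Diyne Enone

A few compounds are considered here, and "the series" means these few. Any claim that something is new, unique, unknown or untested is made for them only; others in the source may bear on it.

Three compounds have been tested in a functional assay on HCT-15 cells (Homo sapiens) for cytotoxicity; on this read-out lower numbers stand for an effect already at smaller amounts and higher numbers for an effect only at larger amounts of compound:

Compound 1, `C=CCCCCCCCC#CC#C/C=C\C(C)=O`: > 50 ug/mL, which is a limit of the assay.
Compound 2, `CCCCCCCC#CC#CC1CC(=O)C=C(C)C1`: 45.1 ug/mL.
Compound 3, `CCCCCCCC#CC#CC1=CC(=O)NCCC1`: > 50 ug/mL, again a limit of the assay.

Compound 1 thus stands at the limit of > 50 ug/mL in this assay, at which 2 of the 3 values shown sit; only compound 2 gives an actual number, and that number is weak. Within the data shown here, no two measured compounds differ in a single place, so no measured step exists to guide the next change. The unmeasured compound 4, `CCCCCCCC#CC#C/C=C\C(C)=O`, differs from compound 1 by hydrogen in place of vinyl on a saturated chain carbon, seven bonds along the chain from a triple-bonded carbon. Without a measured step to lean on, the expectation for a step that the limit leaves unreadable from compound 1 to compound 4 is no change beyond the scatter. Compound 4 is therefore estimated at 60 ug/mL, in the range 25 ug/mL to 150 ug/mL, with a fair chance that only a limit is reported.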

Compound 4, concentration for half-maximal effect: > 50 ug/mL
Compound 4 was reported as a limit; the forecaster's own chance of this, stated with the estimate: 65%; the middle value lies beyond the limit too.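

No size can be read for the change from compound 1 to compound 4, because each is reported only as a limit: the limit of > 50 ug/mL in this assay, at which 3 of the 4 values shown sit. The compounds shown leave open whether hydrogen in place of vinyl alters the effect in this assay at all.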